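The source may hold more compounds than are shown below. What is called first, only, known or untested is meant among the compounds shown, and "the series" means these compounds.

The measured compounds in a functional assay with Cavia porcellus as the target (a lower number here means tighter binding, a higher number weaker binding), are:

Compound 1, `COC(=O)c1ccccc1OCC(O)CNC(C)C`: 5.01 nM
Compound 2, `COC(=O)c1ccccc1OCC(O)CNCCNC(=O)C(C)C`: 7.94 nM
Compound 3, `COC(=O)c1ccccc1OCC(O)CNCCNS(=O)(=O)N(C)C`: 31.6 nM

Compound 2 holds the second highest of these three numbers; its step of a 1.6-fold higher number from compound 1 to compound 2 (0.20 log units; within the scatter) lies within the scatter, while its step of a 4.0-fold higher number from compound 2 to compound 3 (0.60 log units; beyond the scatter) is a modest rise. The unmeasured compound 4, `COC(=O)c1ccccc1OCC(O)CNC(C)(C)CNC(N)=O`, differs from compound 2 by 1-methyl-1-(ureidomethyl)ethyl in place of 2-((isopropylcarbonyl)amino)ethyl on an amine nitrogen. Neither measured step matches this change exactly. The step of a 1.6-fold higher number from compound 1 to compound 2 (0.20 log units; within the scatter) shows that changing the group on this amine nitrogen need not move the number, whereas a 4.0-fold higher number from compound 2 to compound 3 (0.60 log units; beyond the scatter) shows it can rise modestly. A small rise or no step beyond the scatter is therefore expected, as a 1.6-fold higher number from compound 2 to compound 4 (0.20 log units; within the scatter). Compound 4 is estimated at 12.6 nM, between 4 nM and 40 nM.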

Compound 4, dissociation constant: 1.26 nM
Estimate against measurement, compound 4: 10-fold (1.00 log units) above; the measured number lies below the stated range.
By their numbers in this assay, from the lowest: compound 4; then compounds 1 and 2 (each within the scatter of the next); then compound 3.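

In this assay, the group on this amine nitrogen can also lower the number: earlier steps showed only a rise or no shift beyond the scatter, whereas a 6.3-fold lower number from compound 2 to compound 4 (0.80 log units; beyond the scatter) is a fall beyond it. Ureidomethyl in place of hydrogen on the saturated chain carbon gives a 4.0-fold lower number from compound 1 to compound 4 (0.60 log units; beyond the scatter), which is also beyond the scatter. No measurement shown bears on why the number falls. Still open, going by these compounds, is which part of 1-methyl-1-(ureidomethyl)ethyl goes with the fall: 2-ureidoethyl or tert-butyl on this amine nitrogen would separate the ureido group from the branched carbon.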